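Amino for methyl on the aromatic ring

A few compounds are considered here, and "the series" means these few. Any claim that something is new, unique, unknown or untested is made for them only; others in the source may bear on it.

In a functional assay on MGC-803 cells (Homo sapiens) for inhibition, read by CCK-8 assay, with a stated time of 48 h (a lower number here means a stronger inhibitor, a higher number a weaker inhibitor), compound 1 `COc1ccc(CN(C(=O)CSC(=S)N2CCN(C(=O)OC(C)(C)C)CC2)c2cc(OC)c(OC)c(OC)c2)cc1` gives 310 nM as its measured value. In this assay compound 2 `COc1ccc(CN(C(=O)CSC(=S)N2CCN(C(=O)OC(C)(C)C)CC2)c2cc(OC)c(OC)c(OC)c2)cc1C` reads > 20000 nM and this is a limit of the assay, not a number. Compound 3 `COc1ccc(CN(C(=O)CSC(=S)N2CCN(C(=O)OC(C)(C)C)CC2)c2cc(OC)c(OC)c(OC)c2)cc1N` differs from compound 2 by amino in place of methyl on an aromatic carbon, ortho to a methoxy group and meta to a large group (amino in place of methyl on an aromatic carbon). For the measured compounds named here, only one measured step bears on this change: an at least 64-fold higher number from compound 1 to compound 2 (1.80 log units; beyond the scatter) for methyl in place of hydrogen, and it is large. Going by the values given here, no compound with the amino group has been measured yet. Because an at least 64-fold higher number from compound 1 to compound 2 (1.80 log units; beyond the scatter) came with the arrival of the methyl that now leaves, a large move to a lower number is expected in this assay for compound 3. The estimate means an expected at least 13-fold lower number from compound 2 to compound 3 (1.12 log units; beyond the scatter) overall. Compound 3 is estimated at 1500 nM with a range of 150 nM to 15000 nM as the expected span.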

Compound 3, half-maximal inhibitory concentration: 184 nM
Beside the measured number, compound 3's estimate is 8.2-fold (0.91 log units) above it; the measured number falls inside the stated range.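

In this assay, replacing methyl with amino on this ring carbon gives an at least 100-fold lower number from compound 2 to compound 3 (2.03 log units; beyond the scatter) and so restores activity, which shows that the loss seen with methyl does not apply to every group placed here. Set against the compound with only hydrogen at this carbon, the amino group gives a 1.7-fold lower number from compound 1 to compound 3 (0.23 log units; within the scatter) and stays within the scatter, so amino and hydrogen cannot be told apart at this position in this cell test. As far as these compounds go, the true size of the methyl-to-amino step remains unknown, since compound 2 stands at a limit of the assay and not at a number: the limit of > 20000 nM in this assay, at which 1 of the 3 values shown sits.

The compounds shown cannot tell why methyl and amino differ so sharply here. From the compounds shown here alone, whether a hydroxyl, a fluorine or a longer chain such as ethyl on this carbon would follow methyl or amino also remains open.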